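A few compounds are considered here, and "the series" means these few. Any claim that something is new, unique, unknown or untested is made for them only; others in the source may bear on it.

Three compounds share one core and differ only in the group carried on an aromatic carbon of a five-membered aromatic ring with one sulfur. Compound 1 `Cc1ccsc1CN[C@@H]1C[C@H]2C[C@@H]([C@H]1C)C2(C)C` gives 10000 nM in an ADME assay on MDCK cells (Canis lupus familiaris) for cytotoxicity, read by microscopy, with a stated time of 48 h; on this read-out lower numbers stand for higher toxicity in this test and higher numbers for lower toxicity in this test. Compound 2 `CCCCc1ccsc1CN[C@@H]1C[C@H]2C[C@@H]([C@H]1C)C2(C)C` gives 25000 nM in this assay, and compound 3 `C[C@H]1[C@H](NCc2sccc2C2CCCC2)C[C@H]2C[C@@H]1C2(C)C` gives 12500 nM in this assay. Compound 3 thus holds the second highest of the three numbers; its nearest neighbour is compound 1 and its furthest is compound 2, and both gaps remain within the scatter. The step from compound 1 to compound 2 was a 2.5-fold higher number from compound 1 to compound 2 (0.40 log units; beyond the scatter), the only change among these three that passed beyond the scatter.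

Compound 4 `C[C@H]1[C@H](NCc2sccc2-c2ccccc2)C[C@H]2C[C@@H]1C2(C)C` differs from compound 3 by phenyl in place of cyclopentyl on an aromatic carbon. Within the data shown here, two measured steps bear on this change, since each alters the group on the same aromatic carbon: a 1.3-fold higher number from compound 1 to compound 3 (0.10 log units; within the scatter) and a 2.0-fold lower number from compound 2 to compound 3 (0.30 log units; within the scatter). Among the measured compounds shown here, neither moved the number beyond the scatter, and no measured step exchanges a non-aromatic ring for an aromatic one on that carbon. The expectation is therefore no change at the digits printed from compound 3 to compound 4 (within the scatter), that is no step beyond the scatter. Compound 4 is estimated at 12500 nM in this assay, with a range from 6000 nM to 25000 nM.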

Compound 4, minimum cytotoxic concentration: 12500 nM
Beside the measured number, compound 4's estimate shows no gap at the digits printed, and the stated range covers the measured number.
By their numbers in this assay, from the lowest: compounds 1, 3, 4 and 2 (each within the scatter of the next, the first and the last beyond it).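

In this assay, among these compounds, the exchange of a non-aromatic ring for an aromatic one on this carbon, which no earlier step covered, gives no change at the digits printed from compound 3 to compound 4 (within the scatter) and so leaves phenyl and cyclopentyl indistinguishable at this position. Phenyl also stays within the scatter of the two other groups, with a 2.0-fold lower number from compound 2 to compound 4 (0.30 log units; within the scatter) against butyl and a 1.3-fold higher number from compound 1 to compound 4 (0.10 log units; within the scatter) against methyl, so the only step among these four compounds that passes beyond the scatter is still a 2.5-fold higher number from compound 1 to compound 2 (0.40 log units; beyond the scatter) between methyl and butyl. Nothing measured here explains why the ring exchange leaves the number where it stands.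

As far as these compounds go, whether an amine or a carboxylic acid on this aromatic carbon, or a chain longer than butyl, would carry the number beyond the scatter remains open, as does the effect of a fluorine or a methoxy group placed on the phenyl ring itself. All four compounds also keep the shared core unchanged, so these results say nothing about how the same groups would read on a different core.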